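E to Z at the double bond of compound 2

This account rests on a few compounds, and the source may have more. Where it says the series, first, only, none or still open, it means among the compounds named here.

In a functional assay on A549 cells (Homo sapiens) for inhibition (a lower number here means a stronger inhibitor, a higher number a weaker inhibitor), compound 1 (`COc1cc2ccc(CCc3ccc4ccccc4c3)cc2cc1O`) gives 3590 nM as a measured number. Compound 2 (`COc1cc(/C=C/c2ccc(N(C)C)c([N+](=O)[O-])c2)cc(OC)c1OC`) has no number in this assay and stands only at the limit > 5000 nM as its read-out. That value is a limit of the assay and not a measured potency.

Compound 3 (`COc1cc(/C=C\c2ccc(N(C)C)c([N+](=O)[O-])c2)cc(OC)c1OC`) is the next point, and the change from compound 2 is this: the two compounds have the same atoms and bonds and differ only in configuration as drawn: 1 of 1 stereo elements differ; a double bond is drawn E in compound 2 and Z in compound 3 and nothing else. Within the data shown here, no measured pair shows what such a change does in this assay, so the size of the step remains a judgement. A large move towards stronger inhibition is expected, and the estimated at least 33-fold lower number from compound 2 to compound 3 (1.52 log units; beyond the scatter) would lie well beyond the scatter. The estimate for compound 3 is 150 nM with an expected range of 10 nM to 3000 nM in this assay for now.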

Compound 3, half-maximal inhibitory concentration: > 5000 nM
Compound 3 was reported as a limit; the forecaster's own chance of this, stated with the estimate: 10%; middle value at least 33-fold (1.52 log units) from the limit.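

Among these compounds, compound 2 and compound 3 are both reported only as limits in this assay, and no step between them can be read. The compounds shown leave open whether the configuration of the double bond changes inhibition at all in this assay.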